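A few compounds are considered here, and "the series" means these few. Any claim that something is new, unique, unknown or untested is made for them only; others in the source may bear on it.

Three hydroxamic acids built on one shared core were measured in a functional assay on NCI-H23 cells (Homo sapiens) for inhibition, read by sulforhodamine B assay; a lower number here means a stronger inhibitor of growth, a higher number a weaker inhibitor of growth. Compound 1 `Cc1ccccc1CN1CC=C(CCC(=O)NO)C1=O` gives 2500 nM. Compound 3 `Cc1ccc(CN2CC=C(CCC(=O)NO)C2=O)cc1` gives 2500 nM. Compound 2 `O=C(CCC1=CCN(CCCc2ccc(Cl)cc2)C1=O)NO` gives 2520 nM. On these numbers compound 2 stands level with the other two: its gap to compound 1 and its gap to compound 3 both lie within the usual scatter of repeated measurements, so this assay does not tell the three apart.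

Compound 4 `CC(C)(C)c1ccc(CCCN2CC=C(CCC(=O)NO)C2=O)cc1` has not yet been measured in this assay. It differs from compound 2 in one place, (tert-butyl in place of chloro on an aromatic carbon). For the measured compounds named here, no step between two measured compounds shows what this change does; compounds 1 and 3 each differ from compound 2 in more than one place, so they offer only their own numbers for comparison. Compound 1 at 2500 nM, compound 2 at 2520 nM and compound 3 at 2500 nM sit within the scatter of one another although they differ in several places. On that ground only a small step is expected, in either direction or none beyond the scatter, a 1.0-fold lower number from compound 2 to compound 4 (0.00 log units; within the scatter). Compound 4 is therefore estimated at 2500 nM, with a range from 1100 nM to 5500 nM.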

Compound 4, concentration for 50% growth inhibition: 2520 nM
Beside the measured number, compound 4's estimate is 1.0-fold (0.00 log units) below it; the range from low to high includes it.
By their numbers in this assay, from the lowest: compounds 1, 3, 2 and 4 (each within the scatter of the next).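

In this assay, putting tert-butyl in place of chloro on an aromatic carbon gives no change at the digits printed from compound 2 to compound 4 (within the scatter). For the compounds shown here, this is the first comparison that isolates a single change at one place, whereas the earlier compounds differed from one another in several places and offered only their separate numbers. It shows that at this position, on the six-membered aromatic ring and para to a large group, going from one chlorine atom to four carbon heavy atoms leaves the growth inhibition reading within the scatter, but no measurement bearing on this result is available to explain it.

What the compounds shown leave open is whether this tolerance extends beyond these two groups, for instance to an amine or a carboxylic acid on the same aromatic carbon. A single step also cannot say whether tert-butyl in place of chloro would read the same way if the aromatic ring were carried on a longer chain.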